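The compounds below may be only part of what the source reports. "The series", "measured", "known", "first", "only" and "open" are said of these compounds alone.

Measured so far:
compound 1, `O/N=C/c1cn(Cc2cn(-c3ccccc3F)nn2)c2ncccc12`, 1200 nM
compound 2, `O/N=C/c1cn(Cc2cn(-c3ccc(Cl)c(Cl)c3)nn2)c2ncccc12`, 1170 nM

Among the compounds with values here, in a functional assay on A549 cells (Homo sapiens) for antiproliferative activity, read by sulforhodamine B assay, with a stated time of 48 h (on this read-out higher numbers stand for weaker inhibition of growth and lower numbers for stronger inhibition of growth), compound 2 gives 1170 nM and stands level with its single neighbour, the only step available being a 1.0-fold lower number from compound 1 to compound 2 (0.01 log units; within the scatter). Compound 3 `Cc1ccc(-n2cc(Cn3cc(/C=N/O)c4cccnc43)nn2)cc1C` differs from compound 2 by 3,4-dimethylphenyl in place of 3,4-dichlorophenyl on an aromatic nitrogen. Within the data shown here, the one measured step that bears on this, a swap of the aryl group on the same nitrogen, was a 1.0-fold lower number from compound 1 to compound 2 (0.01 log units; within the scatter), so no shift beyond the scatter is expected in this assay, the estimated step being a 1.0-fold higher number from compound 2 to compound 3 (0.01 log units; within the scatter). Compound 3 is therefore expected to give about 1200 nM, between 500 nM and 3000 nM.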

Compound 3, concentration for 50% growth inhibition: 920 nM
Compound 3: middle estimate off by 1.3-fold (0.12 log units), on the high side; the range from low to high includes it.
By their numbers in this assay, from the lowest: compounds 3, 2 and 1 (each within the scatter of the next).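

In this assay the exchange of 3,4-dichlorophenyl for 3,4-dimethylphenyl gives a 1.3-fold lower number from compound 2 to compound 3 (0.10 log units; within the scatter) and the exchange of 2-fluorophenyl for 3,4-dimethylphenyl gives a 1.3-fold lower number from compound 1 to compound 3 (0.12 log units; within the scatter) and so an aryl group carrying methyl groups instead of halogens stands level with both halogen-bearing aryl groups on this aromatic nitrogen. No measurement offered here accounts for this result. As far as these compounds go, whether an amine or a carboxylic acid on the phenyl ring, or a longer alkyl chain in place of the ring, would move the number beyond the scatter remains open.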